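This account rests on a few compounds, and the source may have more. Where it says the series, first, only, none or still open, it means among the compounds named here.

Measured in a functional assay on U-373MG ATCC cells (Homo sapiens) for cytotoxicity, read by MTT assay; a higher number here means a weaker inhibitor, a lower number a stronger inhibitor:
- compound 1 `Oc1ccc(CN(Cc2ccccc2)Cc2ccc(O)c3ncccc23)c2cccnc12`: 357 nM
- compound 2 `Oc1ccc(CN(Cc2cccc(C(F)(F)F)c2)Cc2ccc(O)c3ncccc23)c2cccnc12`: 65 nM
- compound 3 `Oc1ccc(CN(Cc2cccc(I)c2)Cc2ccc(O)c3ncccc23)c2cccnc12`: 5600 nM

Of these three, compound 3 has the highest number, 5600 nM, and so is the weakest inhibitor. Compound 4 `O=C(O)C1CCC(CN(Cc2ccc(O)c3ncccc23)Cc2ccc(O)c3ncccc23)CC1` differs from it in one place: 4-carboxycyclohexyl in place of 3-iodophenyl on a saturated chain carbon bound to an amine nitrogen. Among the compounds with values here, no measured compound carries a carboxy group or a non-aromatic ring in this position, so no measured step tests this change directly. The closest guides are changes on the aromatic ring: a 5.5-fold lower number from compound 1 to compound 2 (0.74 log units; beyond the scatter), a 16-fold higher number from compound 1 to compound 3 (1.20 log units; beyond the scatter) and an 86-fold higher number from compound 2 to compound 3 (1.94 log units; beyond the scatter). These run in both directions, so they give no clear direction for the new change. In this assay, no shift beyond the scatter is expected, though with wide uncertainty. The expected step is a 1.4-fold lower number from compound 3 to compound 4 (0.15 log units; within the scatter). For compound 4 the estimated value is 4000 nM, with an expected range from 600 nM to 25000 nM.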

Compound 4, half-maximal inhibitory concentration: 3730 nM
The estimate for compound 4 lay 1.1-fold (0.03 log units) above the measured number, and the stated range covers the measured number.
By their numbers in this assay, from the lowest: compound 2; then compound 1; then compounds 4 and 3 (each within the scatter of the next).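

In this assay, the step from the iodo compound to 4-carboxycyclohexyl stays within the scatter (a 1.5-fold lower number from compound 3 to compound 4 (0.18 log units; within the scatter)), while the steps from the other two aromatic groups are large (a 10-fold higher number from compound 1 to compound 4 (1.02 log units; beyond the scatter); a 57-fold higher number from compound 2 to compound 4 (1.76 log units; beyond the scatter)). On this chain carbon, then, a non-aromatic ring bearing a carboxy group gives a number far higher than phenyl or 3-(trifluoromethyl)phenyl, and level with 3-iodophenyl. No measurement here explains these shifts. The compounds shown leave open whether the carboxy group or the loss of the aromatic ring drives the change, which a plain cyclohexyl or a 4-carboxyphenyl group would help separate.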